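Replacing the aryl amide with a pyrrolidinylethyl amide

This account rests on a few compounds, and the source may have more. Where it says the series, first, only, none or still open, it means among the compounds named here.

Measured compounds:
compound 1, `O=C(O)CCC(=O)OCCCCCCSc1ccc([N+](=O)[O-])c2nonc12`, 740 nM
compound 2, `O=C(CCC(=O)OCCCCCCSc1ccc([N+](=O)[O-])c2nonc12)Nc1cccc(Cl)c1`, 1090 nM
compound 3, `O=C(CCC(=O)OCCCCCCSc1ccc([N+](=O)[O-])c2nonc12)Nc1ccc(F)cc1`, 1740 nM

All three were tested in an ADME assay on HUVEC cells (Homo sapiens) for cytotoxicity, read by MTT assay, with a stated time of 72 h; a higher number here means a weaker inhibitor, a lower number a stronger inhibitor. The steps of a 1.5-fold higher number from compound 1 to compound 2 (0.17 log units; within the scatter) and a 1.6-fold higher number from compound 2 to compound 3 (0.20 log units; within the scatter) both fall within the scatter, so compound 2 cannot be set apart from either neighbour; only a 2.4-fold higher number from compound 1 to compound 3 (0.37 log units; beyond the scatter) reaches beyond it, and modestly. Compound 4, `O=C(CCC(=O)OCCCCCCSc1ccc([N+](=O)[O-])c2nonc12)NCCN1CCCC1`, has not been measured. Its change from compound 2 is 2-(pyrrolidin-1-yl)ethyl in place of 3-chlorophenyl on an amide-type nitrogen. For the measured compounds named here, no measured step swaps an aromatic ring on the amide nitrogen for a chain bearing a non-aromatic ring, so nothing bears on it directly; the measured steps show only that changes at this amide position have stayed small. The number for compound 4 is therefore expected to stay close to compound 2, as a 1.0-fold higher number from compound 2 to compound 4 (0.00 log units; within the scatter), with no step beyond the scatter. Compound 4 is estimated at 1100 nM, within 400 nM to 3000 nM.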

Compound 4, half-maximal inhibitory concentration: 6070 nM
The estimate for compound 4 lay 5.5-fold (0.74 log units) below the measured number, outside the stated range (above it).
By their numbers in this assay, from the lowest: compounds 1, 2 and 3 (each within the scatter of the next, the first and the last beyond it); then compound 4.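

In this assay, this amide position proves able to move the number beyond the scatter: 2-(pyrrolidin-1-yl)ethyl in place of 3-chlorophenyl gives a 5.6-fold higher number from compound 2 to compound 4 (0.75 log units; beyond the scatter), and in place of 4-fluorophenyl it gives a 3.5-fold higher number from compound 3 to compound 4 (0.54 log units; beyond the scatter). (2-(Pyrrolidin-1-yl)ethyl)amino in place of hydroxy on the carbonyl carbon gives an 8.2-fold higher number from compound 1 to compound 4 (0.91 log units; beyond the scatter), the largest step in this set. Nothing measured here accounts for these steps. Still open, going by these compounds, is whether they follow from the amine or from losing the aromatic ring. A plain butyl amide, without an amine, could help separate the two.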